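The compounds below may be only part of what the source reports. "The series", "measured", "known", "first", "only" and "open" are said of these compounds alone.

Working notes on the series. In an ADME assay on GES1 cells (Homo sapiens) for inhibition, read by MTT assay, with a stated time of 72 h (a higher number here means a weaker inhibitor, a lower number a stronger inhibitor), compound 1 `Cc1cc(Nc2cc(-c3ccccc3)[nH]n2)n2nc(SCc3ccc(F)cc3)nc2n1` gives 35500 nM. Compound 3 `Cc1cc(Nc2cc(-c3ccc(F)cc3)[nH]n2)n2nc(SCc3ccc(Br)cc3)nc2n1` gives 34200 nM in this assay, and compound 2 `Cc1cc(Nc2ccn(Cc3ccc(F)cc3)n2)n2nc(SCc3ccc(Br)cc3)nc2n1` gives 40500 nM; compound 1 sits among these with no gap to either that exceeds the scatter, so the three cannot be separated on these numbers. Going by the values given here, no step between two measured compounds that differ in a single place is available. Compound 4 `Cc1cc(Nc2cc(-c3ccccc3)[nH]n2)n2ncnc2n1` differs from compound 1 by hydrogen in place of (4-fluorobenzyl)sulfanyl on an aromatic carbon. Among the compounds with values here, no measured pair shows what removing this group does, so the step from compound 1 to compound 4 is expected to be modest, a 1.4-fold higher number from compound 1 to compound 4 (0.15 log units; within the scatter), if anything toward a weaker inhibitor. Compound 4 is expected to give 50000 nM in this assay, within 20000 nM to 130000 nM.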

Compound 4, half-maximal inhibitory concentration: > 50000 nM
Compound 4: no number, only a limit (the forecaster's own chance of this, stated with the estimate: 30%); the middle value lies on the limit itself.
By their numbers in this assay, from the lowest: compounds 3, 1 and 2 (each within the scatter of the next). At a limit, above all of these: compound 4.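

Compound 4 gives a limit of the assay and not a number: the limit of > 50000 nM in this assay, at which 1 of the 4 values shown sits. Going by these compounds alone, this is the first change read at a single place: hydrogen in place of (4-fluorobenzyl)sulfanyl gives an at least 1.4-fold higher number from compound 1 to compound 4 (0.14 log units; that floor lies within the scatter). The direction of this floor is toward a weaker inhibitor, but the floor itself does not separate the two compounds, and the full size of the step cannot be read.

From the compounds shown here alone, whether an amine or a methylsulfanyl group on this aromatic carbon would give a number in this assay stays open. Going by these compounds, the part of (4-fluorobenzyl)sulfanyl that matters here, if any, also stays open.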